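From piperidin-1-yl to 2,6-dimethylpiperidin-1-yl

A few compounds are considered here, and "the series" means these few. Any claim that something is new, unique, unknown or untested is made for them only; others in the source may bear on it.

In an ADME assay on microsomes from liver (Rattus norvegicus) for metabolic stability, read by LC-MS, using NADPH, at 37 degrees C (on this read-out higher numbers stand for a longer-lived compound and lower numbers for a shorter-lived compound), compound 3 `Cc1ccccc1-c1nc(CN2CCC(C(=O)NCCCN3CCCCC3)CC2)c(C)o1` gives > 0.5 h, which is a limit and not a number. Compound 2 `Cc1ccccc1-c1nc(CN2CCC(C(=O)NCCCN3CCC(C)(C)CC3)CC2)c(C)o1`, with 4,4-dimethylpiperidin-1-yl, gives > 0.5 h, also a limit. Compound 1 `Cc1ccccc1-c1nc(CN2CCC(C(=O)NCCCN3CC(C)(C)CC(C)(C)C3)CC2)c(C)o1` gives a true number, 0.095 h.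

Compound 4 `Cc1ccccc1-c1nc(CN2CCC(C(=O)NCCCN3[C@H](C)CCC[C@@H]3C)CC2)c(C)o1` differs from compound 3 as follows: 2,6-dimethylpiperidin-1-yl in place of piperidin-1-yl on a saturated chain carbon, three bonds along the chain from an amide-type nitrogen. Within the data shown here, two measured steps bear on this change: an at least 5.2-fold higher number from compound 1 to compound 3 (0.72 log units; beyond the scatter), and an at least 5.2-fold higher number from compound 1 to compound 2 (0.72 log units; beyond the scatter). Both lie beyond the scatter, and both lead away from compound 1, whose ring carries the most methyl groups. A modest fall is therefore expected, with the result possibly still at the limit. The expected change is an at least 1.6-fold lower number from compound 3 to compound 4 (0.22 log units; that floor lies within the scatter). For compound 4 the estimated half-life is 0.3 h, with an expected range of 0.1 h to 0.7 h.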

Compound 4, half-life: > 0.5 h
Compound 4: no number, only a limit; the forecaster's own chance of this, stated with the estimate: 35%; middle value at least 1.6-fold (0.22 log units) away from the limit.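

Compound 4 also gives a limit and not a number, so 2,6-dimethylpiperidin-1-yl joins 4,4-dimethylpiperidin-1-yl among the groups that carry two methyl groups without reaching a measurable half-life. The change from the group of 10 heavy atoms to this one gives an at least 5.2-fold higher number from compound 1 to compound 4 (0.72 log units; beyond the scatter). The steps to compound 4 from compound 3 and compound 2 cannot be read, because all three compounds sit at the same limit: the limit of > 0.5 h in this assay, at which 3 of the 4 values shown sit.

From the compounds shown here alone, how far these three compounds lie past that limit remains open. So does the outcome for morpholin-4-yl or a longer chain at this place.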